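A Longer Ester Arm on a Weakly Active Core

A few compounds are considered here, and "the series" means these few. Any claim that something is new, unique, unknown or untested is made for them only; others in the source may bear on it.

Compound 3 `CCCOC(=O)c1ccc(-c2nn(Cc3ccccc3)c3ccccc23)cc1` carries a propoxycarbonyl group on its outer aromatic ring. In a functional assay on cells (Platelet, Homo sapiens) for inhibition (a higher number here means a weaker inhibitor, a lower number a stronger inhibitor), compound 3 reaches only the assay limit of > 10000 nM, so no number is known for it (the limit of > 10000 nM in this assay, at which 1 of the 3 values shown sits). Two related compounds with a shorter ester and a chlorine on the benzyl ring are more informative: compound 1 `CCOC(=O)c1ccc(-c2nn(Cc3ccccc3Cl)c3ccccc23)cc1` gives 230 nM in this assay, and compound 2 `CCOC(=O)c1ccc(-c2nn(Cc3ccc(Cl)cc3)c3ccccc23)cc1` gives 120 nM. For the measured compounds named here, the single measured step, a 1.9-fold lower number from compound 1 to compound 2 (0.28 log units; within the scatter), concerns the chlorine position and not the ester, so it does not bear on the change now considered.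

Compound 4 `CCOC(=O)/C=C/c1ccc(-c2nn(Cc3ccccc3)c3ccccc23)cc1` differs from compound 3 in one place: 2-(ethoxycarbonyl)ethenyl in place of propoxycarbonyl on an aromatic carbon. Going by the values given here, no measured step here addresses an extension of the ester away from the ring, so the expectation rests on compound 3 alone. Compound 4 is therefore expected to stay weak, near 8000 nM, within 1500 nM to 40000 nM, meaning an estimated step of an at least 1.2-fold lower number from compound 3 to compound 4 (0.09 log units; that floor lies within the scatter).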

Compound 4, half-maximal inhibitory concentration: > 10000 nM
Compound 4 was reported as a limit (the forecaster's own chance of this, stated with the estimate: 50%); at least 1.2-fold (0.09 log units) between middle value and limit.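

In this assay compound 3 gives only the limit > 10000 nM. Compound 4 also gives only a limit, > 10000 nM, so the step between these two compounds cannot be read. As far as these compounds go, how strongly either compound inhibits, and whether swapping propoxycarbonyl for 2-(ethoxycarbonyl)ethenyl changes that, remains open.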